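The compounds below may be only part of what the source reports. "The series", "measured", "known", "first", "only" and "open" are said of these compounds alone.

Measured compounds:
- compound 1, `C#CCOc1ccc(/C=C/C(=O)c2cccc(OC)c2)cc1OC`: 5590 nM
- compound 2, `C#CCOc1ccc(/C=C/C(=O)c2cccn2C)cc1OC`: > 50000 nM
- compound 3, `C#CCOc1ccc(/C=C/C(=O)c2cccc(C)c2)cc1OC`: 8820 nM

The three compounds share a core and differ only in the group attached to the carbonyl carbon. In a functional assay on CCRF-CEM cells (Homo sapiens) for cytotoxicity, with a stated time of 72 h (on this read-out higher numbers stand for weaker inhibition and lower numbers for stronger inhibition), compound 1 gives 5590 nM, the lowest of the two numbers shown. Compound 3 gives 8820 nM, and the step of a 1.6-fold higher number from compound 1 to compound 3 (0.20 log units; within the scatter) is within the scatter, so the two cannot be ordered. For compound 2 the value > 50000 nM is a limit of the assay, not a number (the limit of > 50000 nM in this assay, at which 1 of the 3 values shown sits). The step of an at least 8.9-fold higher number from compound 1 to compound 2 (0.95 log units; beyond the scatter) therefore marks a clear loss.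

Compound 4, `C#CCOc1ccc(/C=C/C(=O)c2ccc(OC)c(OC)c2)cc1OC`, has not yet been measured. It differs from compound 1 by methoxy in place of hydrogen on an aromatic carbon. Within the data shown here, none of the measured steps adds a group at this position; the nearest comparison is a 1.6-fold higher number from compound 1 to compound 3 (0.20 log units; within the scatter), which shows that swapping the group already present on that ring changes little, while an at least 8.9-fold higher number from compound 1 to compound 2 (0.95 log units; beyond the scatter) shows that replacing the whole ring costs much. A second methoxy on the same ring is a smaller change than either, so in this assay no step beyond the scatter is expected for compound 4, the estimated step being a 1.2-fold lower number from compound 1 to compound 4 (0.09 log units; within the scatter). Compound 4 is thus expected to give about 4500 nM, with a plausible range from 1500 nM to 14000 nM.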

Compound 4, half-maximal inhibitory concentration: 8650 nM
The estimate for compound 4 lay 1.9-fold (0.28 log units) below the measured number; low and high end bracket the measured number.
By their numbers in this assay, from the lowest: compounds 1, 4 and 3 (each within the scatter of the next). At a limit, above all of these: compound 2.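

Adding a methoxy on an aromatic carbon of the six-membered ring, ortho to a methoxy group and para to a large group, gives in this assay a 1.5-fold higher number from compound 1 to compound 4 (0.19 log units; within the scatter) and so does not allow the two compounds to be ordered. The earlier steps shown here only swapped the group already on this ring or replaced the whole ring, whereas this step shows that the ring can carry one more methoxy at this place with no change beyond the scatter, at least on this cytotoxicity read-out. Nothing measured here accounts for this result, and the one note available, on the assay limit, does not bear on it.

Methoxy is a small group, so it remains open whether this same place would also accept an amine, a carboxylic acid or a longer chain such as butoxy, any of which could show whether the read-out responds to this position at all. On these data alone, it is also open whether a hydroxyl here, in place of the added methoxy, would leave the number as little changed.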